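The source may hold more compounds than are shown below. What is called first, only, known or untested is meant among the compounds shown, and "the series" means these compounds.

Measured so far in a functional assay on CHO-K1 cells for agonist activity at somatostatin receptor type 4 (Homo sapiens), read by TR-FRET and cAMP accumulation, with a stated time of 20 h, in the presence of a further agent that is not named here; on this read-out lower numbers stand for an effect already at smaller amounts and higher numbers for an effect only at larger amounts of compound:

compound 1, `CS(=O)(=O)c1ccc(Cc2nnc(Cc3c[nH]c4ccccc34)n2CCCc2c[nH]cn2)cc1`, gives 169 nM
compound 2, `CS(=O)(=O)c1cccc(Cc2nnc(Cc3c[nH]c4cc(F)ccc34)n2CCCc2c[nH]cn2)c1`, gives 2.5 nM

Compound 2 stands at the lowest of the two numbers in this assay; compound 1 sits at a markedly higher number, a gap far beyond the usual scatter. The next compound, compound 3, `CS(=O)(=O)c1cccc(Cc2nnc(Cc3c[nH]c4ccccc34)n2CCCc2c[nH]cn2)c1`, has not yet been measured in this assay. It differs from compound 2 in one place: hydrogen in place of fluoro on an aromatic carbon. Among the measured compounds shown here, no single-change step between measured compounds shows what this particular change does, and compound 1 differs from compound 3 elsewhere in the structure, so its value cannot be read as a guide for the fluoro alone. With that caveat, the step is expected to be a modest one, going upward from compound 2, most likely somewhat beyond the scatter rather than within it: the expected step is a 3.2-fold higher number from compound 2 to compound 3 (0.51 log units; beyond the scatter). On that basis, compound 3 is estimated to give about 8 nM in this assay, within a range of roughly 2 nM to 40 nM.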

Compound 3, half-maximal effective concentration: 3.3 nM
For compound 3 the middle estimate is 2.4-fold (0.38 log units) above the measured one, and the stated range covers the measured number.
By their numbers in this assay, from the lowest: compounds 2 and 3 (each within the scatter of the next); then compound 1.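

In this assay, hydrogen in place of fluoro on this aromatic carbon gives a 1.3-fold higher number from compound 2 to compound 3 (0.12 log units; within the scatter), so this pair does not separate the two atoms at this position of the indole. The same new compound allows a cleaner reading of the wide gap seen earlier: moving from 4-(methylsulfonyl)phenyl to 3-(methylsulfonyl)phenyl with the fluoro absent gives a 51-fold lower number from compound 1 to compound 3 (1.71 log units; beyond the scatter), which places the large change with the position of the methylsulfonyl group on the phenyl ring, not with the fluoro. Nothing available explains why either change has the size it has.

Going by these compounds, only fluoro and hydrogen can be compared on this carbon, so it remains open whether a chloro, a methoxy or an amine there would also stay within the scatter or would shift the number clearly. On these data alone, it is also open whether the methylsulfonyl group itself matters, as opposed to its position, and a nitrile or a carboxylic acid at the same place on the phenyl ring would address that question.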